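The source may hold more compounds than are shown below. What is called first, only, known or untested is meant among the compounds shown, and "the series" means these compounds.

Compound 1, `CC1=CC[C@H](C(C)(C)NC(=S)N/N=C/c2ccccc2O)CC1`: in a functional assay on U-251 cells (Homo sapiens) for inhibition, read by sulforhodamine B assay, with a stated time of 48 h (on this read-out lower numbers stand for stronger inhibition of growth and higher numbers for weaker inhibition of growth), compound 1 gives 10600 nM.
Compound 2, `CC1=CC[C@H](C(C)(C)NC(=S)N/N=C/c2cccc(Cl)c2)CC1`: in this assay compound 2 gives 35800 nM.
Compound 3, `CC1=CC[C@H](C(C)(C)NC(=S)N/N=C/c2ccc(Cl)cc2)CC1`: in this assay compound 3 gives a value that is a limit of the assay and not a number, > 100000 nM.

Among the two numbers measured, compound 1 has the lowest, meaning the strongest growth inhibition; the nearest is compound 2, with a 3.4-fold higher number from compound 1 to compound 2 (0.53 log units; beyond the scatter). Compound 3 sits at the limit of > 100000 nM in this assay, at which 1 of the 3 values shown sits.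

Compound 4, `CC1=CC[C@H](C(C)(C)NC(=S)N/N=C/c2ccccc2[N+](=O)[O-])CC1`, differs from compound 1 in one place: nitro in place of hydroxy on an aromatic carbon. Among the measured compounds shown here, no measured step swaps the hydroxy for a nitro. Two steps, though, remove that hydroxy from compound 1 in favour of a chlorine, and both give a higher number: a 3.4-fold higher number from compound 1 to compound 2 (0.53 log units; beyond the scatter) and an at least 9.4-fold higher number from compound 1 to compound 3 (0.97 log units; beyond the scatter). These steps also move the new group, as the names 3-chlorophenyl and 4-chlorophenyl show, and the two chlorinated compounds differ from each other, an at least 2.7-fold higher number from compound 2 to compound 3 (0.44 log units; beyond the scatter), so they bear only loosely on compound 4. Taken together, they suggest that losing the hydroxy on compound 1 costs some growth inhibition. A modest upward step in this assay is therefore expected, a 2.8-fold higher number from compound 1 to compound 4 (0.45 log units; beyond the scatter), with a real chance that the assay again reports only its limit. Compound 4 is estimated at 30000 nM, with a range from 10000 nM to 100000 nM.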

Compound 4, concentration for total growth inhibition: > 100000 nM
Compound 4: no number, only a limit; the forecaster's own chance of this, stated with the estimate: 25%; at least 3.3-fold (0.52 log units) between middle value and limit.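

Nitro in place of hydroxy on the same aromatic carbon, ortho to a large group, gives an at least 9.4-fold higher number from compound 1 to compound 4 (0.97 log units; beyond the scatter), and this is the first step that replaces the hydroxy without also moving the new group. The growth inhibition of compound 1 in this assay therefore falls away with a change at this position alone, so the earlier rises cannot be put down only to the chlorine sitting elsewhere on the ring. The result for compound 4 is a limit of the assay and not a number, so the step gives only a smallest possible size, and compound 4 cannot be placed any more exactly: the limit of > 100000 nM in this assay, at which 2 of the 4 values shown sit.

The compounds shown leave open whether any replacement of the hydroxy at this position has the same cost, or whether the cost is specific to nitro, and a methoxy or an amine on the same aromatic carbon would help to separate the two. They also leave open how a chlorine would behave on this carbon, which would show how much the position matters apart from the group placed there.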